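Clearance of an aminopropoxy analogue with a hydroxylated amine

The source may report more compounds than this note shows. Statements on the series, on what has been measured and on what is new or still open speak of the compounds shown alone.

Compound 1, `N[C@H]1CC[C@@H](Oc2ccc([C@H]3CC[C@]4(CC3)OOC3(O4)C4CC5CC(C4)CC3C5)cc2)CC1`, is read in an ADME assay on microsomes from liver (Homo sapiens) for metabolic stability, read by LC-MS, tested at 1 uM (on this read-out higher numbers stand for fast clearance and lower numbers for slow clearance), only as a limit, giving < 7 mL.min-1.g-1. Compound 2, `NCCCOc1ccc([C@H]2CC[C@]3(CC2)OOC2(O3)C3CC4CC(C3)CC2C4)cc1`, is likewise read only as a limit, giving < 7 mL.min-1.g-1. Compound 3, `CC1(C)CC(O)(COc2ccc([C@H]3CC[C@]4(CC3)OOC3(O4)C4CC5CC(C4)CC3C5)cc2)CC(C)(C)N1`, gives 14 mL.min-1.g-1 in this assay. The step that the two limits leave unreadable from compound 1 to compound 2; the steps of an at least 2.0-fold higher number from compound 1 to compound 3 (0.30 log units; that floor lies within the scatter) and an at least 2.0-fold higher number from compound 2 to compound 3 (0.30 log units; that floor lies within the scatter) both reach only a floor that lies within the scatter. The two limits are summarised by the limit of < 7 mL.min-1.g-1 in this assay, at which 2 of the 3 values shown sit.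

Compound 4, `CC(C)(O)CNCCCOc1ccc([C@H]2CC[C@]3(CC2)OOC2(O3)C3CC4CC(C3)CC2C4)cc1`, differs from compound 1 in one place: 3-((2-hydroxy-2-methylpropyl)amino)propyl in place of 4-aminocyclohexyl on an oxygen on an aromatic ring. Compound 4 shares the 3-aminopropyl chain of compound 2 with a 2-hydroxy-2-methylpropyl group on the nitrogen. Given that compound 2 sits at the limit with < 7 mL.min-1.g-1 and that compound 3 moves no further than a floor within the scatter, compound 4 is expected to sit near the low end of this assay, with the step of a number no lower from compound 1 to compound 4 (the limit leaves the size open) expected to stay within the scatter. Compound 4 is estimated at 7 mL.min-1.g-1, with a range from 3 mL.min-1.g-1 to 15 mL.min-1.g-1.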

Compound 4, intrinsic clearance in microsomes: 8 mL.min-1.g-1
Beside the measured number, compound 4's estimate is 1.1-fold (0.06 log units) below it, within the range that was stated.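

In this assay, the 2-hydroxy-2-methylpropyl group on the amine nitrogen of the 3-aminopropyl chain gives compound 4 a number that can be read as a value, whereas compound 2 stands only as a limit. The two steps from the limits, an at least 1.1-fold higher number from compound 2 to compound 4 (0.05 log units; that floor lies within the scatter) and an at least 1.1-fold higher number from compound 1 to compound 4 (0.05 log units; that floor lies within the scatter), are floors only and show no change beyond the scatter: the limit of < 7 mL.min-1.g-1 in this assay, at which 2 of the 4 values shown sit. The result against the other hydroxylated amine, a 1.8-fold lower number from compound 3 to compound 4 (0.24 log units; within the scatter), means that on this oxygen the open 3-((2-hydroxy-2-methylpropyl)amino)propyl chain and the ring-bearing group of compound 3 cannot be told apart.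

The compounds shown leave open how a plain 2-methylpropyl group on the amine nitrogen, without the hydroxyl, would read in this assay. They also leave open how a longer chain would read there.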